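From formyl to ethoxycarbonyl on a shared core

This account rests on a few compounds, and the source may have more. Where it says the series, first, only, none or still open, it means among the compounds named here.

Going by the values given here, in a functional assay (Homo sapiens) (on this read-out higher numbers stand for weaker inhibition and lower numbers for stronger inhibition), compound 2 `Nc1nc2ccnc(-c3cccc(C=O)c3)n2n1` gives 700 nM, the lower of the two numbers measured so far. Compound 1 `Cc1cccc(-c2nccc3nc(N)nn23)c1` gives 5500 nM. Among the compounds with values here, the only measured step is a 7.9-fold lower number from compound 1 to compound 2 (0.90 log units; beyond the scatter), modest and beyond the scatter, with formyl in place of methyl on an aromatic carbon. Compound 3 `CCOC(=O)c1cccc(-c2nccc3nc(N)nn23)c1` changes compound 2 at that same group: ethoxy in place of hydrogen on a carbonyl carbon, which turns formyl into ethoxycarbonyl. Within the data shown here, no measured step covers this change directly, so the expectation rests on compound 2 at 700 nM and on the carbonyl being kept. A modest rise in the number is expected, a 1.9-fold higher number from compound 2 to compound 3 (0.27 log units; within the scatter), though a step within the scatter would not surprise. For compound 3 the estimated value in this assay is 1300 nM, with an expected range from 400 nM to 4500 nM.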

Compound 3, half-maximal inhibitory concentration: 11500 nM
Beside the measured number, compound 3's estimate is 8.8-fold (0.95 log units) below it, and the stated range ends below it.
By their numbers in this assay, from the lowest: compound 2; then compound 1; then compound 3.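

In this assay a carbonyl at this aromatic carbon is not enough to keep the gain seen with formyl: there is a 16-fold higher number from compound 2 to compound 3 (1.22 log units; beyond the scatter) when ethoxy replaces the hydrogen on the carbonyl carbon, a large change that more than cancels the earlier gain. There is also a 2.1-fold higher number from compound 1 to compound 3 (0.32 log units; beyond the scatter), so ethoxycarbonyl gives a higher number than methyl even though it keeps the carbonyl that formyl has. Nothing measured here explains either step.

The compounds shown leave open whether the loss belongs to ethoxy itself or would follow any group placed on that carbonyl carbon. A carboxylic acid, a primary amide or a methyl ketone at the same place would help separate these readings, and a hydroxymethyl group would test whether the carbonyl is needed at all.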